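Piperidine substituent variation in a TRPV1 antagonist series

The compounds below may be only part of what the source reports. "The series", "measured", "known", "first", "only" and "open" are said of these compounds alone.

Measured compounds:
compound 1, `CC(C(=O)NCc1ccc(C(F)(F)F)nc1NCc1ccccc1)c1ccc(NS(C)(=O)=O)c(F)c1`: 15.8 nM
compound 2, `CC(C(=O)NCc1ccc(C(F)(F)F)nc1N1CCC(c2ccccc2)CC1)c1ccc(NS(C)(=O)=O)c(F)c1`: 0.6 nM
compound 3, `CC(C(=O)NCc1ccc(C(F)(F)F)nc1N1CCC(Cc2cc(F)cc(F)c2)CC1)c1ccc(NS(C)(=O)=O)c(F)c1`: 0.4 nM

All three were tested in a functional assay on CHO-K1 cells for antagonist activity at transient receptor potential cation channel subfamily V member 1 (Homo sapiens), read by FLIPR; on this read-out lower numbers stand for stronger inhibition and higher numbers for weaker inhibition. Compound 3 gives the lowest number of the three, though its gap to compound 2, a 1.5-fold lower number from compound 2 to compound 3 (0.18 log units; within the scatter), is within the scatter, so the two cannot be ordered; only compound 1 stands clearly apart, with a 26-fold lower number from compound 1 to compound 2 (1.42 log units; beyond the scatter).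

Compound 4, `CC(C(=O)NCc1ccc(C(F)(F)F)nc1N1CCC(O)CC1)c1ccc(NS(C)(=O)=O)c(F)c1`, differs from compound 3 in one place: hydroxy in place of 3,5-difluorobenzyl on a saturated ring carbon. Within the data shown here, no measured step removes the aromatic group from the saturated ring altogether, so the nearest guide is the large step of a 26-fold lower number from compound 1 to compound 2 (1.42 log units; beyond the scatter), which shows how much the group on this part of the core can move the number, while a 1.5-fold lower number from compound 2 to compound 3 (0.18 log units; within the scatter) shows that trading phenyl for 3,5-difluorobenzyl barely matters. Loss of the whole aromatic group in favour of hydroxy is expected to weaken compound 4 in this assay, with a step of a 38-fold higher number from compound 3 to compound 4 (1.57 log units; beyond the scatter), but the size is uncertain. Compound 4 is expected to give about 15 nM, plausibly between 3 nM and 80 nM.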

Compound 4, inhibition constant: "not active" (no number reported)
Compound 4: no number reported; no gap can be computed for the estimate.
By their numbers in this assay, from the lowest: compounds 3 and 2 (each within the scatter of the next); then compound 1.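

Among these compounds, compound 4 is reported as "not active" with no number, so no step from compound 3 to compound 4 can be read. The compounds shown leave open whether the loss of 3,5-difluorobenzyl or the entry of hydroxy decides this result, and nothing shown gives its cause.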